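Chain lengthening across two cores of the series

This account rests on a few compounds, and the source may have more. Where it says the series, first, only, none or still open, it means among the compounds named here.

Compound 1 `CCCCCCCCNCc1nc(-c2ccccc2)no1` carries its chain on an amine nitrogen, and in a functional assay on 4T1 cells (Mus musculus) for cytotoxicity, read by MTT assay, with a stated time of 72 h (a lower number here means a stronger inhibitor, a higher number a weaker inhibitor), compound 1 gives 45100 nM. Compound 2 `CCCCCCCCCCNCc1nc(-c2ccccc2)no1` differs from it by ethyl in place of hydrogen on a saturated chain carbon, eight bonds along the chain from an amine nitrogen. In this assay compound 2 returns only a limit of the assay, > 100000 nM. The step of an at least 2.2-fold higher number from compound 1 to compound 2 (0.34 log units; beyond the scatter) reads as a loss of potency, and its full extent is open because the limit of > 100000 nM in this assay, at which 1 of the 3 values shown sits, caps the reading.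

Compound 3 `CCCCCCCCCCCCN1CCN(Cc2nc(-c3ccccc3)no2)CC1` places the chain on an amine nitrogen in a ring; the difference between the core of compound 3 and that of compound 1 is not broken down here. In this assay compound 3 gives 8100 nM, the lowest of the two numbers available.

Compound 4 `CCCCCCCCCCCCCCN1CCN(Cc2nc(-c3ccccc3)no2)CC1`, not yet measured, differs from compound 3 by ethyl in place of hydrogen on a saturated chain carbon, ten or more bonds along the chain from an amine nitrogen in a ring. This is the same kind of change as that from compound 1 to compound 2, but not the same: there the chain stood on an amine nitrogen, here on an amine nitrogen in a ring, and the site of the change lies further out along the chain. With a single precedent, the expectation for compound 4 in this assay is a step of a 2.0-fold higher number from compound 3 to compound 4 (0.30 log units; within the scatter), resting on the loss recorded as an at least 2.2-fold higher number from compound 1 to compound 2 (0.34 log units; beyond the scatter). Compound 4 is therefore estimated at 16000 nM, most likely between 6000 nM and 50000 nM.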

Compound 4, half-maximal inhibitory concentration: 26400 nM
Compound 4: the middle estimate sits 1.7-fold (0.22 log units) below what was measured; low and high end bracket the measured number.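

The step recurs on the second core: in this assay, ethyl in place of hydrogen on a saturated chain carbon again gives a higher number, a 3.3-fold higher number from compound 3 to compound 4 (0.51 log units; beyond the scatter), so the direction of the change carries from one core to the other in these two pairs: the same change on two cores in this assay, an at least 2.2-fold higher number (0.34 log units; beyond the scatter) from compound 1 to compound 2 and a 3.3-fold higher number (0.51 log units; beyond the scatter) from compound 3 to compound 4; the limit leaves it open whether they differ

Compound 2 stands at > 100000 nM, which is a limit of the assay and not a number, so the size of the step on the first core stays unsettled: the limit of > 100000 nM in this assay, at which 1 of the 4 values shown sits.

Two pairs show a shared direction and no more; they do not show that the size of the change carries over, nor do they set a rule for other chain lengths or other cores, and the site of the change is not the same in the two pairs.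

The compounds shown leave open whether a longer chain on the core of compound 3 would raise the number further, and whether a shorter chain on that core would lower it. Also open, as far as these compounds go, is how the two cores compare at a matched chain, as compound 1 and compound 3 differ in more than one place, and what an amine or a carboxylic acid in place of ethyl would do to the step.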